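Swapping a chlorophenyl for a pyridyl on the alkyne

The source may hold more compounds than are shown below. What is called first, only, known or untested is meant among the compounds shown, and "the series" means these compounds.

Measured so far:
- compound 1 `O=C1c2ccc(C#Cc3ccccc3)nc2CCN1C1CCCC1`: 5.9 nM
- compound 2 `O=C1c2ccc(C#Cc3ccc(Cl)cc3)nc2CCN1C1CCCC1`: 979 nM

Among the measured compounds shown here, in a functional assay on HEK293 cells for positive allosteric modulation of metabotropic glutamate receptor 5 (Homo sapiens), read by FLIPR and calcium flux (on this read-out lower numbers stand for an effect already at smaller amounts and higher numbers for an effect only at larger amounts of compound), compound 2 gives the higher of the two numbers measured so far; its nearest neighbour is compound 1, and the only measured step, a 170-fold higher number from compound 1 to compound 2 (2.22 log units; beyond the scatter), separates them. Compound 3 `O=C1c2ccc(C#Cc3cccnc3)nc2CCN1C1CCCC1` differs from compound 2 by pyridin-3-yl in place of 4-chlorophenyl on a triple-bonded carbon. This change undoes the chloro substitution that marked the step from compound 1 to compound 2 and at the same time puts a ring nitrogen into the aromatic ring. For the measured compounds named here, the measured step bears on the first part of this change: in this assay removing the chloro reverses a 170-fold higher number from compound 1 to compound 2 (2.22 log units; beyond the scatter), so a large drop toward the number of compound 1 is expected, while the effect of the ring nitrogen has no measured counterpart here. For compound 3 the expected step is therefore a 49-fold lower number from compound 2 to compound 3 (1.69 log units; beyond the scatter). Compound 3 is estimated at 20 nM, with a range of 4 nM to 150 nM.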

Compound 3, half-maximal effective concentration: 748 nM
For compound 3 the middle estimate is 37-fold (1.57 log units) below the measured one, outside the stated range (above it).
By their numbers in this assay, from the lowest: compound 1; then compounds 3 and 2 (each within the scatter of the next).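

In this assay pyridin-3-yl in place of 4-chlorophenyl gives a 1.3-fold lower number from compound 2 to compound 3 (0.12 log units; within the scatter) and so leaves the number effectively unmoved. Pyridin-3-yl in place of phenyl gives a 130-fold higher number from compound 1 to compound 3 (2.10 log units; beyond the scatter) and is therefore a large step of the same kind as a 170-fold higher number from compound 1 to compound 2 (2.22 log units; beyond the scatter) on this triple-bonded carbon. Among these three compounds, then, the low number belongs only to the unsubstituted phenyl of compound 1, and two different alterations of that ring, a chloro group and a ring nitrogen, land within the scatter of each other. Nothing available explains why these two changes end up so close together. As far as these compounds go, whether a fluoro or methyl group on the phenyl would keep the number of compound 1 remains open. So does the outcome for pyridin-2-yl or pyridin-4-yl at this place.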